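A few compounds are considered here, and "the series" means these few. Any claim that something is new, unique, unknown or untested is made for them only; others in the source may bear on it.

Compound 1, `Cc1cc(OCCCS(C)(=O)=O)cc(C)c1-c1cccc(COc2ccc(OC(C)C(=O)O)cc2)c1`: 389 nM
Compound 2, `Cc1cc(OCc2cccc(-c3c(C)cc(OCCCS(C)(=O)=O)cc3C)c2)ccc1OCC(=O)O`: 153 nM

Both compounds were measured in a functional assay on CHO cells for agonist activity at Free fatty acid receptor 1 (Homo sapiens), read by fluorescence and calcium flux; a higher number here means that more compound is needed for the effect, a lower number that less compound is needed. Among the measured compounds shown here, compound 2 holds the lowest of the two numbers; its nearest neighbour is compound 1, and the single measured step, a 2.5-fold lower number from compound 1 to compound 2 (0.41 log units; beyond the scatter), separates them by more than the usual scatter.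

Compound 3, `Cc1cc(OCCCS(C)(=O)=O)cc(C)c1-c1cccc(COc2ccc(OCC(=O)O)c(Cl)c2)c1`, has not yet been measured. It differs from compound 2 in one place: chloro in place of methyl on an aromatic carbon. For the measured compounds named here, the only measured step, from compound 1 to compound 2, changed the whole aryl ether part of the molecule and says nothing about swapping a methyl for a chloro on that ring, so no measured step bears directly on this change. With nothing in the data pointing either way, the expectation is a step no larger than the scatter, in no particular direction, that is a 1.0-fold higher number from compound 2 to compound 3 (0.02 log units; within the scatter). Compound 3 is therefore estimated to give 160 nM in this assay, with a plausible range from 60 nM to 420 nM.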

Compound 3, half-maximal effective concentration: 92.6 nM
Compound 3: the middle estimate sits 1.7-fold (0.24 log units) above what was measured; measured number inside the range.
By their numbers in this assay, from the lowest: compounds 3 and 2 (each within the scatter of the next); then compound 1.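

Among the compounds shown here, on the aromatic carbon ortho to the carboxymethoxy group, chloro in place of methyl gives a 1.7-fold lower number from compound 2 to compound 3 (0.22 log units; within the scatter) in this assay, so this position accepts either group without a change beyond the scatter, which the earlier compounds could not show. The 4-(carboxymethoxy)-3-chlorophenyl group also separates clearly from the 4-(1-carboxyethoxy)phenyl group, with a 4.2-fold lower number from compound 1 to compound 3 (0.62 log units; beyond the scatter) on the same core, so the distance from compound 1 seen with the methyl group in compound 2 holds with chloro as well. Nothing available gives a reason for either step.

The compounds shown leave open whether this position needs a substituent at all, since the plain hydrogen, fluoro, methoxy and trifluoromethyl do not stand among them beside the carboxymethoxy group. They also leave the two differences from compound 1 unseparated. The ring substituent and the extra methyl on the acid chain change together, and only a compound pairing the 1-carboxyethoxy chain with chloro, or the carboxymethoxy chain with an unsubstituted ring, could tell them apart.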